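The compounds below may be only part of what the source reports. "The series", "measured", "known", "first", "only" and "open" are said of these compounds alone.

Working notes on the series. Of the compounds shown here, three have been read so far in a functional assay on RS4-11 cells (Homo sapiens) for inhibition, read by CCK-8 assay, with a stated time of 48 h (on this read-out higher numbers stand for weaker inhibition and lower numbers for stronger inhibition), and only one gives a number. Compound 3 (`Nc1ccc(Oc2ccccc2-c2ccc(S(=O)(=O)NCCNC(=O)Nc3ccc(Cl)cc3)s2)cc1`) gives 13600 nM in this read-out. Compound 1 (`COc1ccc(Oc2ccccc2-c2ccsc2S(=O)(=O)N2CCN(C(=S)Nc3ccc([N+](=O)[O-])cc3)CC2)cc1OC`) gives only a limit (> 50000 nM). Among the measured compounds shown here, compound 2 (`COc1ccc(Oc2ccc([N+](=O)[O-])cc2-c2ccsc2S(=O)(=O)N2CCN(C(=S)Nc3ccc(Cl)cc3)CC2)cc1OC`) also gives only a limit (> 50000 nM) and belongs with the limit of > 50000 nM in this assay, at which 2 of the 3 values shown sit, so far, so it offers no number to step from.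

Compound 4 (`COc1ccc(Oc2ccc([N+](=O)[O-])cc2-c2ccsc2S(=O)(=O)N2CCN(C(=S)Nc3ccc([N+](=O)[O-])cc3)CC2)cc1OC`) carries nitro in place of chloro on an aromatic carbon, para to a large group (nitro in place of chloro on an aromatic carbon), so 4-chlorophenyl becomes 4-nitrophenyl. That 4-nitrophenyl group already stands in compound 1, whose result is a limit (> 50000 nM). On that basis no step beyond the scatter is expected in this assay, and no direction can be assigned. The estimate amounts to a number no higher from compound 2 to compound 4 (the limit leaves the size open) and is expected to stay within the scatter. For compound 4 the expected value is 50000 nM with an estimated range from 25000 nM to 100000 nM, and a report as a limit is the likelier outcome.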

Compound 4, half-maximal inhibitory concentration: > 50000 nM
Compound 4: no number, only a limit; the forecaster's own chance of this, stated with the estimate: 75%; the middle value lies on the limit itself.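

Compound 4 gives > 50000 nM in this assay, which is a limit and not a number. The steps to compound 4 from compound 1 and from compound 2 cannot be read, as all three share one limit: the limit of > 50000 nM in this assay, at which 3 of the 4 values shown sit.

The compounds shown leave open whether nitro in place of chloro or of hydrogen changes the read-out at all in this assay.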